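Fluoro for bromo on the shared core of compound 2

This account rests on a few compounds, and the source may have more. Where it says the series, first, only, none or still open, it means among the compounds named here.

Compound 2, `Cc1[nH]c2ccc(Br)cc2c1SC1CCNCC1`, is measured in a functional assay on the whole organism with Mus musculus as the target, in the hot plate test; a lower number here means that less compound is needed, a higher number that more compound is needed for the effect. There compound 2 gives 3.1 mg/kg, the lowest of the two numbers seen so far. Among the measured compounds shown here, its only neighbour is compound 1, `Cc1[nH]c2ccc(Cl)cc2c1SC1CCNCC1`, which in this assay gives 9.9 mg/kg. For the measured compounds named here, the two differ only in one halogen on the aromatic ring, and that single step, a 3.2-fold lower number from compound 1 to compound 2 (0.50 log units; beyond the scatter), is the one comparison that bears on what comes next.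

The new compound, compound 3, is `Cc1[nH]c2ccc(F)cc2c1SC1CCNCC1`. It differs from compound 2 in one place: fluoro in place of bromo on an aromatic carbon. The measured step shows that swapping chloro for bromo at this position lowered the number by a modest but real amount. Fluoro is the next halogen in the same series, beyond chloro, so for compound 3 the expectation is a step in the opposite direction, toward a higher number, likely somewhat larger than the change seen between compound 1 and compound 2, because that change is a 3.2-fold lower number from compound 1 to compound 2 (0.50 log units; beyond the scatter). For compound 3 the estimated step is a 4.8-fold higher number from compound 2 to compound 3 (0.68 log units; beyond the scatter). Compound 3 is therefore expected to give about 15 mg/kg, with a plausible range from 6 mg/kg to 40 mg/kg.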

Compound 3, dose for half-maximal effect: 12.7 mg/kg
Beside the measured number, compound 3's estimate is 1.2-fold (0.07 log units) above it; measured number inside the range.
By their numbers in this assay, from the lowest: compound 2; then compounds 1 and 3 (each within the scatter of the next).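

Replacing bromo with fluoro gives a 4.1-fold higher number from compound 2 to compound 3 (0.61 log units; beyond the scatter), whereas replacing chloro with fluoro gives only a 1.3-fold higher number from compound 1 to compound 3 (0.11 log units; within the scatter), so in this assay the fluoro and chloro compounds cannot be told apart. At this position, then, the three halogens do not form an even series: compound 2 stands alone with the lowest number, while compound 1 and compound 3 sit together, a shape that the first pair alone could not reveal. Nothing available here explains why bromo separates from the other two halogens.

Going by these compounds, it remains open whether iodo at the same aromatic carbon would lower the number further, or whether a group other than a halogen, such as methyl, methoxy or nitrile, could match bromo there. On these data alone, it is also open whether the gap between bromo and the other two halogens would persist if the shared core were changed elsewhere, for example with a longer chain in place of the methyl group.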